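Boron-containing chalcone series: aryl ketone variation and cytotoxicity

This account rests on a few compounds, and the source may have more. Where it says the series, first, only, none or still open, it means among the compounds named here.

Measured so far:
Compound 1 `O=C(/C=C/c1ccc2c(c1)B(O)OC2)c1ccc(-c2ccccc2)cc1`: 9500 nM
Compound 2 `O=C(/C=C/c1ccc2c(c1)B(O)OC2)c1ccc(Cl)cc1`: 9300 nM
Compound 3 `CSc1ccc(C(=O)/C=C/c2ccc3c(c2)B(O)OC3)cc1`: 10300 nM

In a functional assay on HCT-116 cells (Homo sapiens) for cytotoxicity, read by MTT assay, with a stated time of 48 h (a lower number here means a stronger inhibitor, a higher number a weaker inhibitor), compound 2 gives 9300 nM; this is the lowest of the three numbers, but the steps of a 1.0-fold lower number from compound 1 to compound 2 (0.01 log units; within the scatter) and a 1.1-fold higher number from compound 2 to compound 3 (0.04 log units; within the scatter) are both within the scatter, so the three measured compounds cannot be told apart. The next compound, compound 4 `Nc1cccc(C(=O)/C=C/c2ccc3c(c2)B(O)OC3)c1`, differs from compound 2 as follows: 3-aminophenyl in place of 4-chlorophenyl on a carbonyl carbon. Within the data shown here, no measured step bears directly on this change; the three measured steps all concern one aromatic carbon and were all flat, including a 1.1-fold higher number from compound 1 to compound 3 (0.04 log units; within the scatter). On that basis compound 4 is expected to show no step beyond the scatter, a 1.1-fold higher number from compound 2 to compound 4 (0.03 log units; within the scatter). The estimated value for compound 4 is 10000 nM, with a range from 5000 nM to 20000 nM.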

Compound 4, half-maximal inhibitory concentration: 4500 nM
Estimate against measurement, compound 4: 2.2-fold (0.35 log units) above; the measured number lies below the stated range.
By their numbers in this assay, from the lowest: compound 4; then compounds 2, 1 and 3 (each within the scatter of the next).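

In this assay the aryl group on the carbonyl carbon is not silent, with a 2.1-fold lower number from compound 2 to compound 4 (0.32 log units; beyond the scatter) as a modest step and the first in this series beyond the scatter. The earlier swaps on one aromatic carbon gave no such separation. Nothing available accounts for the step.

The change replaces both the group and its ring position, so the contribution of the amine itself remains unresolved. Going by these compounds, whether a hydroxyl group, an acetamide or a dimethylamino group would hold or extend the step also remains open.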